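From Trifluoromethoxy to Hydroxy in a Growth Inhibition Series

The source may hold more compounds than are shown below. What is called first, only, known or untested is meant among the compounds shown, and "the series" means these compounds.

Of the compounds shown here, three sharing one core have been measured in a functional assay on SiHa cells (Homo sapiens) for inhibition, read by sulforhodamine B assay; on this read-out higher numbers stand for weaker inhibition of growth and lower numbers for stronger inhibition of growth. Compound 1 `Oc1cccc2[nH]c(-c3ccc(-c4ccc(-c5ccccc5)cc4)cc3)nc12` gives 9710 nM. Compound 2 `Oc1cccc2[nH]c(-c3ccc(-c4ccc(-c5ccc(C(F)(F)F)cc5)cc4)cc3)nc12`, which carries trifluoromethyl, gives 3720 nM, and compound 3 `Oc1cccc2[nH]c(-c3ccc(-c4ccc(-c5ccc(OC(F)(F)F)cc5)cc4)cc3)nc12`, which carries trifluoromethoxy, gives 8410 nM.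

Compound 3 stands close to compound 1 on these numbers, with a gap of a 1.2-fold lower number from compound 1 to compound 3 (0.06 log units; within the scatter). Its gap to the trifluoromethyl analogue is larger, at a 2.3-fold higher number from compound 2 to compound 3 (0.35 log units; beyond the scatter).

Compound 4 `Oc1ccc(-c2ccc(-c3ccc(-c4nc5c(O)cccc5[nH]4)cc3)cc2)cc1` differs from compound 3 as follows: hydrogen in place of trifluoromethyl on an oxygen on an aromatic ring. This is hydrogen in place of trifluoromethyl on an oxygen on an aromatic ring, which turns trifluoromethoxy into hydroxy. For the measured compounds named here, no measured pair shows this change directly, so the evidence is indirect. The largest substituent effect seen so far, a 2.6-fold lower number from compound 1 to compound 2 (0.42 log units; beyond the scatter), is only modest, and the other two steps are no larger. A large move is therefore not expected, and the expectation is for no clear shift in either direction beyond the scatter. The estimated step is a 1.2-fold lower number from compound 3 to compound 4 (0.08 log units; within the scatter). For compound 4 the expected value is 7000 nM, with an estimated range of 3000 nM to 16000 nM.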

Compound 4, concentration for 50% growth inhibition: 2410 nM
Compound 4: the middle estimate sits 2.9-fold (0.46 log units) above what was measured, and the stated range ends above it.
By their numbers in this assay, from the lowest: compounds 4 and 2 (each within the scatter of the next); then compounds 3 and 1 (each within the scatter of the next).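

In this assay, the group on this oxygen turns out to matter, even though trifluoromethoxy had stood level with the unsubstituted compound 1: removing trifluoromethyl to leave hydroxy gives a clear gain in growth inhibition (a 3.5-fold lower number from compound 3 to compound 4 (0.54 log units; beyond the scatter)). For the compounds shown here, measured against hydrogen on the aromatic carbon, hydroxy gives the largest step so far, though it is still modest (a 4.0-fold lower number from compound 1 to compound 4 (0.61 log units; beyond the scatter)), while hydroxy and trifluoromethyl cannot be told apart (a 1.5-fold lower number from compound 2 to compound 4 (0.19 log units; within the scatter)), so two very different groups arrive at the same level and compound 3, with trifluoromethoxy, is the one that stays behind. Nothing available here explains why this change on the oxygen has such an effect, and the numbers record only its size.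

The compounds shown leave open whether the gain needs the hydrogen on this oxygen, a question that methoxy in the same place would address. They also leave open whether an amine or a carboxylic acid on the aromatic carbon would match hydroxy and trifluoromethyl or would move the number further in either direction.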